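A few compounds are considered here, and "the series" means these few. Any claim that something is new, unique, unknown or untested is made for them only; others in the source may bear on it.

Measured compounds in an assay on HeLa cells for inhibition of Indoleamine 2,3-dioxygenase 1 (Homo sapiens), read by spectrophotometry, with a stated time of 24 h; a higher number here means that more compound is needed for the effect, a lower number that less compound is needed:
compound 1 `CC(=O)Nc1ccc(S(=O)(=O)NNc2ccc(C)cc2)cc1`, compound 1 gives 1170 nM
compound 2 `CC(=O)Nc1ccc(S(=O)(=O)NNc2ccc(C#N)cc2)cc1`, compound 2 gives 1390 nM

Going by the values given here, compound 2 stands within the scatter of compound 1, the only other measured compound, the step being a 1.2-fold higher number from compound 1 to compound 2 (0.07 log units; within the scatter). Compound 3 `CC(=O)Nc1ccc(S(=O)(=O)NNc2ccc(C(F)(F)F)cc2)cc1` carries the change (trifluoromethyl in place of cyano on an aromatic carbon). Among the compounds with values here, the one measured step at this position, a 1.2-fold higher number from compound 1 to compound 2 (0.07 log units; within the scatter), bears on it only loosely, since it exchanges methyl for cyano rather than cyano for trifluoromethyl, and it stayed within the scatter. On that basis no step beyond the scatter is expected in this assay. Compound 3 is therefore expected near 1300 nM, range 500 nM to 3500 nM, an expected step of a 1.1-fold lower number from compound 2 to compound 3 (0.03 log units; within the scatter).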

Compound 3, half-maximal effective concentration: 181 nM
Beside the measured number, compound 3's estimate is 7.2-fold (0.86 log units) above it, and the stated range ends above it.
By their numbers in this assay, from the lowest: compound 3; then compounds 1 and 2 (each within the scatter of the next).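

In this assay this position can move the number beyond the scatter, which the exchange of methyl for cyano did not show. Trifluoromethyl gives a 7.7-fold lower number from compound 2 to compound 3 (0.89 log units; beyond the scatter) and also a 6.5-fold lower number from compound 1 to compound 3 (0.81 log units; beyond the scatter) so it stands apart from both earlier groups, which remain within the scatter of each other. Nothing available on these compounds accounts for this step.

As far as these compounds go, whether the lower number is specific to trifluoromethyl stays open, and a chlorine atom, a methoxy group or a pentafluoroethyl chain here would test that. From the compounds shown here alone, whether the step carries over with changes elsewhere on the shared core also stays open.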